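Chlorophenyl position swap in a hydroxyphenyl-pyridine series

A few compounds are considered here, and "the series" means these few. Any claim that something is new, unique, unknown or untested is made for them only; others in the source may bear on it.

Compound 1 `Oc1ccc(-c2cc(-c3cccc(Cl)c3)nc(-c3ccccn3)c2)cc1` is the reference point. In an assay on isolated protein for inhibition of DNA topoisomerase 1 (Homo sapiens), with a stated time of 30 min, tested at 100 uM (a lower number here means a weaker effect, a higher number a stronger effect of the compound at the concentration tested), compound 1 gives 59.4%; on the numbers shown it stands as the reference against which compound 2 and compound 3 are read, both of which fall within the scatter of it. Compound 2 `Oc1ccc(-c2cc(-c3cccc(Cl)c3)nc(-c3cccs3)c2)cc1` gives 52.4% in this assay, with a number 7 percentage points lower from compound 1 to compound 2 (within the scatter). Compound 3 `Oc1ccc(-c2cc(-c3cccnc3)nc(-c3cccc(Cl)c3)c2)cc1` gives 55.2% in this assay, with a number 4.2 percentage points lower from compound 1 to compound 3 (within the scatter). Between compound 2 and compound 3 the pyridin-3-yl group is a number 2.8 percentage points higher from compound 2 to compound 3 (within the scatter).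

Compound 4 `Oc1ccc(-c2cc(-c3ccc(Cl)cc3)nc(-c3ccccn3)c2)cc1` is not yet measured. It differs from compound 1 in 4-chlorophenyl in place of 3-chlorophenyl on an aromatic carbon. Among the compounds with values here, every measured step so far changes the pyridin-2-yl group or its replacement; none touches the chlorophenyl group, so there is no direct precedent for this change. All three measured steps stayed within the scatter, and the shared core is otherwise unchanged. Compound 4 is therefore expected to show no step beyond the scatter, a number 1.4 percentage points lower from compound 1 to compound 4 (within the scatter). The estimate for compound 4 in this assay is 58%, expected to lie between 42% and 72%.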

Compound 4, a percentage reported as inhibition, at one concentration (the size of the read-out at that concentration, not a potency): 12.7%
Estimate against measurement, compound 4: 45.3 percentage points above; measured number outside the range, below it.
By their numbers in this assay, from the lowest: compound 4; then compounds 2, 3 and 1 (each within the scatter of the next).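

In this assay, moving the chlorine gives a number 46.7 percentage points lower from compound 1 to compound 4 (beyond the scatter) even though the two compounds contain the same atoms, making this the only step shown that lies beyond the scatter. Compounds 1, 2 and 3 all carry 3-chlorophenyl, so their agreement within the scatter covers only exchanges of the pyridin-2-yl group and says nothing about the chlorophenyl group, where the placement of the chlorine clearly matters for this series. No measurement shown accounts for the loss.

As far as these compounds go, it remains open whether the loss is specific to chlorine at this placement or would also follow with a fluorine or a methoxy group in its place. Also open, from the compounds shown here alone, is whether 4-chlorophenyl gives a similar loss alongside thiophen-2-yl or pyridin-3-yl.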